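A few compounds are considered here, and "the series" means these few. Any claim that something is new, unique, unknown or untested is made for them only; others in the source may bear on it.

In an ADME assay on microsomes from liver (Homo sapiens) for pharmacokinetics, read by LC-MS, with a stated time of 60 min, tested at 1 uM (a higher number here means faster removal of the compound, a lower number slower removal), compound 1 `O=C(NCc1ccc(S(=O)(=O)C2CCCCC2)cc1)N1Cc2ccncc2C1` gives 16 mL/min/kg, compound 2 `O=C(NCc1ccc(S(=O)(=O)C2CCOCC2)cc1)N1Cc2ccncc2C1` gives 6 mL/min/kg and compound 3 `O=C(NCc1ccc(S(=O)(=O)C2CCCOC2)cc1)N1Cc2ccncc2C1` gives 7 mL/min/kg. Compound 3 stands level with compound 2 and under compound 1. On the sulfonyl sulfur, oxan-4-yl for cyclohexyl gave a 2.7-fold lower number from compound 1 to compound 2 (0.43 log units; beyond the scatter), oxan-3-yl for cyclohexyl gave a 2.3-fold lower number from compound 1 to compound 3 (0.36 log units; beyond the scatter), and exchanging the two oxanyl groups gave a 1.2-fold higher number from compound 2 to compound 3 (0.07 log units; within the scatter). Compound 4 `CCC(=O)N1CCC(S(=O)(=O)c2ccc(CNC(=O)N3Cc4ccncc4C3)cc2)CC1` carries 1-propanoylpiperidin-4-yl in place of oxan-3-yl on a sulfonyl sulfur. For the measured compounds named here, no measured compound holds a propanoyl group, so these steps bear only indirectly. The largest of them, a 2.7-fold lower number from compound 1 to compound 2 (0.43 log units; beyond the scatter), is modest, so no change beyond the scatter is expected. The expected step is a 1.3-fold higher number from compound 3 to compound 4 (0.11 log units; within the scatter). For compound 4 the estimate is 9 mL/min/kg, with an expected range of 4 mL/min/kg to 20 mL/min/kg.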

Compound 4, clearance: 11 mL/min/kg
Estimate against measurement, compound 4: 1.2-fold (0.09 log units) below; measured number inside the range.
By their numbers in this assay, from the lowest: compounds 2, 3, 4 and 1 (each within the scatter of the next, the first and the last beyond it).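

In this assay the 1-propanoylpiperidin-4-yl group on the sulfonyl sulfur stays within the scatter of every earlier group (a 1.6-fold higher number from compound 3 to compound 4 (0.20 log units; within the scatter)) (a 1.8-fold higher number from compound 2 to compound 4 (0.26 log units; within the scatter)) (a 1.5-fold lower number from compound 1 to compound 4 (0.16 log units; within the scatter)). The earlier compounds shown here separated cyclohexyl from the two oxanyl groups, whereas compound 4 cannot be assigned to either side, even with 10 heavy atoms in place of the 6 of oxan-3-yl. No measurement on hand accounts for this. Open, as far as these compounds go, is how the piperidine ring and the propanoyl group each bear on the number. A piperidine with a free amine or a longer acyl chain would test this.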